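Chloro for methoxy in the bromophenoxy thiosemicarbazone series

The source may hold more compounds than are shown below. What is called first, only, known or untested is meant among the compounds shown, and "the series" means these compounds.

Compounds measured so far in an ADME assay on L929 cells (Mus musculus) for cytotoxicity, read by resazurin assay, with a stated time of 96 h; a higher number here means that more compound is tolerated, a lower number that less compound is tolerated:
compound 1, `NC(=S)N/N=C(/COc1ccc(Br)cc1)c1ccccc1`, < 27500 nM
compound 2, `COc1ccc(/C(COc2ccc(Br)cc2)=N\NC(N)=S)cc1`, < 25400 nM
compound 3, `NC(=S)N/N=C(/COc1ccc(Br)cc1)c1ccc(F)cc1`, < 26200 nM

Each of these three values is a limit of this assay and not a number. Compound 1 sits at the limit of < 27500 nM in this assay, at which 1 of the 3 values shown sits. Compound 2 sits at the limit of < 25400 nM in this assay, at which 1 of the 3 values shown sits. Compound 3 sits at the limit of < 26200 nM in this assay, at which 1 of the 3 values shown sits. Compound 2 therefore stands at a limit, as do the two other values shown, so no order among the three can be read.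

The step to compound 4, `NC(=S)N/N=C(/COc1ccc(Br)cc1)c1ccc(Cl)cc1`, is chloro in place of methoxy on an aromatic carbon. The measured steps that bear on it are a step that the two limits leave unreadable from compound 2 to compound 3 and a step that the two limits leave unreadable from compound 1 to compound 2, both on the same aromatic carbon; their sizes cannot be read because both ends are limits. The step that the two limits leave unreadable from compound 1 to compound 3 is likewise unreadable. No readable step exists in this assay, so for compound 4 no step beyond the scatter can be expected in either direction, and the most likely outcome is again a limit.

Compound 4 is estimated at 25000 nM, with a range from 10000 nM to 25100 nM; the expected step from compound 2 is a step that the limit leaves unreadable from compound 2 to compound 4.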

Compound 4, half-maximal cytotoxic concentration: 25100 nM
Compound 4: the middle estimate sits 1.0-fold (0.00 log units) below what was measured; the range from low to high includes it.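

In this assay compound 4 gives 25100 nM. Compound 1, compound 2 and compound 3 stand only at limits, so none of the steps from them to compound 4 can be read. Going by these compounds, whether hydrogen, methoxy, fluoro or chloro on this aromatic carbon makes any difference to the tolerated concentration remains open.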